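This account rests on a few compounds, and the source may have more. Where it says the series, first, only, none or still open, it means among the compounds named here.

Working notes on the series. Among the measured compounds shown here, compound 1 `Cc1ccc(-c2cc(Cl)ccc2OCc2ccc(F)cc2)n1-c1cc(NS(C)(=O)=O)cc(C(=O)O)c1` gives in an assay on CHO cells for displacement of a labelled ligand from prostaglandin E2 receptor EP1 subtype (Homo sapiens) (on this read-out higher numbers stand for weaker inhibition and lower numbers for stronger inhibition), a value of 1.59 nM, the lowest of the two numbers measured so far. Compound 2 `Cc1ccc(-c2cc(Cl)ccc2OCc2ccccc2)n1-c1cc(Br)cc(C(=O)O)c1` gives in this assay a value of 5.01 nM; the two compounds differ in more than one place, so only the two values themselves are compared here. Compound 3 `CC(=O)Nc1cc(C(=O)O)cc(-n2c(C)ccc2-c2cc(Cl)ccc2OCc2ccc(F)cc2)c1` is not yet measured. Relative to compound 1 it carries acetyl in place of methylsulfonyl on a nitrogen on an aromatic ring. For the measured compounds named here, no measured pair covers this change, so the size of the step is an expectation only: a modest rise in the number is expected, a 2.5-fold higher number from compound 1 to compound 3 (0.40 log units; beyond the scatter). Compound 3 is therefore estimated at 4 nM, with a range from 1.5 nM to 12 nM.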

Compound 3, half-maximal inhibitory concentration: 2.51 nM
Estimate against measurement, compound 3: 1.6-fold (0.20 log units) above; low and high end bracket the measured number.
By their numbers in this assay, from the lowest: compounds 1, 3 and 2 (each within the scatter of the next, the first and the last beyond it).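

In this assay, acetyl in place of methylsulfonyl on this nitrogen gives a 1.6-fold higher number from compound 1 to compound 3 (0.20 log units; within the scatter), so the two compounds cannot be told apart. This first single-change pair shows that the methylsulfonyl group is not required for a low nanomolar number in this series, at least against acetyl. Nothing available explains why the two groups read alike.

Still open, as far as these compounds go, is whether a longer acyl chain such as butanoyl, or a free amine on the aromatic ring, would stay in the same range.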